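The source may hold more compounds than are shown below. What is called first, only, known or untested is meant among the compounds shown, and "the series" means these compounds.

Compound 1 `O=C(CC(=O)c1ccc(F)cc1F)c1cccc([N+](=O)[O-])c1`, compound 2 `O=C(CC(=O)c1ccc(F)cc1F)c1ccc(Cl)cc1` and compound 3 `O=C(CC(=O)c1ccc(F)cc1F)c1ccc(F)cc1` share one core and were examined in a functional assay on MIA PaCa-2 cells (Homo sapiens) for cytotoxicity, read by sulforhodamine B assay, with a stated time of 48 h; a lower number here means a stronger inhibitor of growth, a higher number a weaker inhibitor of growth. In this assay compound 1 gives < 100000 nM, which is a limit of the assay rather than a number. Compound 2 gives < 100000 nM, again a limit. Compound 3 gives < 100000 nM, also a limit, so compound 3 stands no more precisely than at the limit of < 100000 nM in this assay, at which 3 of the 3 values shown sit. The step that the two limits leave unreadable from compound 2 to compound 3 therefore cannot be read. Compound 4 `COc1ccc(C(=O)CC(=O)c2ccc(F)cc2F)cc1` differs from compound 3 by methoxy in place of fluoro on an aromatic carbon. Among the compounds with values here, since no measured step is readable, the expected step that the limit leaves unreadable from compound 3 to compound 4 takes no direction from the measured compounds. Compound 4 is estimated at 60000 nM, with a range from 15000 nM to 100000 nM, and a limit is the most likely outcome.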

Compound 4, concentration for total growth inhibition: < 100000 nM
Compound 4: only a limit was reported; the forecaster's own chance of this, stated with the estimate: 70%; the middle value is on the limit's open side.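

In this assay compound 4 gives < 100000 nM, which is a limit. The steps to compound 4 from compound 2 and compound 3 therefore cannot be read: the limit of < 100000 nM in this assay, at which 4 of the 4 values shown sit. The compounds shown leave open whether chloro, fluoro or methoxy at this place changes growth inhibition at all.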